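Hydroxy to Methylsulfanyl: An Expected Loss of Inhibition

The source may report more compounds than this note shows. Statements on the series, on what has been measured and on what is new or still open speak of the compounds shown alone.

Compound 1 `CCCc1nnc(SC)n2c(CCC)nc(C)c12`: > 48000 nM
Compound 2 `CCCc1nc(C)c2c(CC)nnc(O)n12`: 15600 nM

Going by the values given here, in a functional assay for inhibition, with Homo sapiens as the target (on this read-out higher numbers stand for weaker inhibition and lower numbers for stronger inhibition), compound 2 gives 15600 nM, the only number recorded. Compound 1, which also carries methylsulfanyl, reaches only the limit > 48000 nM in this assay. Compound 3 `CCCc1nc(C)c2c(CC)nnc(SC)n12` differs from compound 2 in that (methylsulfanyl in place of hydroxy on an aromatic carbon). Among the compounds with values here, no step between measured compounds has been characterised, so the change is weighed against the limit of > 48000 nM in this assay, at which 1 of the 2 values shown sits, alone. Because (the limit of > 48000 nM in this assay, at which 1 of the 2 values shown sits), the step is expected to weaken inhibition beyond the usual scatter, a 2.9-fold higher number from compound 2 to compound 3 (0.46 log units; beyond the scatter). Compound 3 is therefore estimated at 45000 nM, ranging from 15000 nM to 150000 nM.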

Compound 3, half-maximal inhibitory concentration: > 48000 nM
Compound 3: only a limit was reported (the forecaster's own chance of this, stated with the estimate: 50%); at least 1.0-fold (0.02 log units) between middle value and limit.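

At this aromatic carbon between two ring nitrogen atoms, methylsulfanyl in place of hydroxy now has a step of its own in this assay, an at least 3.0-fold higher number from compound 2 to compound 3 (0.48 log units; beyond the scatter), so the change weakens inhibition beyond the scatter. For compound 3 the reading of > 48000 nM is a limit. The step from compound 1 to compound 3, hydrogen in place of methyl on the saturated chain, cannot be read, and both compounds sit at one limit: the limit of > 48000 nM in this assay, at which 2 of the 3 values shown sit.

Going by these compounds, how much weaker compound 3 truly is stays open. So does whether an amine or a methoxy group at this carbon would keep the inhibition seen with hydroxy.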